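The compounds below may be only part of what the source reports. "The series", "measured", "known", "first", "only" and "open" are said of these compounds alone.

Measured compounds and their results in a functional assay on K562 cells (Homo sapiens) for cytotoxicity, read by trypan blue exclusion, with a stated time of 96 h; a lower number here means a stronger inhibitor, a higher number a weaker inhibitor:

Compound 1, `COc1ccc(/C=C/S(=O)(=O)Cc2ccc(OC)c([N+](=O)[O-])c2)cc1`, gives 25000 nM.
Compound 2, `COc1ccc(/C=C/S(=O)(=O)Cc2ccc(OC)c(N)c2)cc1`, gives 2500 nM.
Compound 3, `COc1ccc(CS(=O)(=O)/C=C/c2c(OC)cccc2OC)c([N+](=O)[O-])c1`, gives 50000 nM.

Compound 4, `COc1ccc(CS(=O)(=O)/C=C/c2c(OC)cccc2OC)c(N)c1`, has not yet been measured in this assay. Its difference from compound 3 is amino in place of nitro on an aromatic carbon. The step from compound 1 to compound 2 is of the same kind, (amino in place of nitro on an aromatic carbon), and it gave a 10-fold lower number from compound 1 to compound 2 (1.00 log units; beyond the scatter). The two changes are not the same, though: in compound 2 the amino sits ortho to a methoxy group and meta to a large group, while in compound 4 it sits ortho to a large group and meta to a methoxy group. How the core of compound 3 differs from the core of compound 1 is not broken down here; their two values lie within the usual scatter of each other.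

Given that the same kind of change produced a 10-fold lower number from compound 1 to compound 2 (1.00 log units; beyond the scatter), the step from compound 3 to compound 4 is expected to be of similar size, an 8.3-fold lower number from compound 3 to compound 4 (0.92 log units; beyond the scatter), with a wide margin because only one such step is available for comparison. Compound 4 is therefore estimated at 6000 nM, between 2000 nM and 20000 nM.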

Compound 4, half-maximal inhibitory concentration: 750 nM
Estimate against measurement, compound 4: 8.0-fold (0.90 log units) above; measured number outside the range, below it.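

In this assay, putting amino in place of nitro on the newer core gave a 67-fold lower number from compound 3 to compound 4 (1.82 log units; beyond the scatter), a lower number in the same direction as on the earlier core. Set side by side, the two steps differ by more than repeat measurements would explain: the same change on two cores in this assay, a 10-fold lower number (1.00 log units; beyond the scatter) from compound 1 to compound 2 and a 67-fold lower number (1.82 log units; beyond the scatter) from compound 3 to compound 4, 6.7-fold (0.82 log units) apart, beyond the scatter of two such steps. The direction therefore held in both pairs, but the size did not carry over unchanged, and two pairs cannot show whether the gap comes from the rest of the core or from where the amino sits on its ring, nor can they give a rule for any third core.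

The compounds shown leave open whether another group in the same place, such as a hydroxyl, an acetamide or a dimethylamino group, would give a number like those of the amino compounds. They also leave open how amino in place of nitro would behave on a core carrying a different number of methoxy groups.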